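From Butyl to Phenyl: an Expected Inhibition Value

The source may report more compounds than this note shows. Statements on the series, on what has been measured and on what is new or still open speak of the compounds shown alone.

Of the compounds shown here, two have so far been measured in a physicochemical assay, with a stated time of 6 min, tested at 0.1 mg/mL; a higher number here means more inhibition at the concentration tested (going by the name of the read-out), a lower number less inhibition. Compound 1, `CCCCOC(=O)Nc1ccc([Se]C#N)cc1`, gives 12.6% in this assay, the higher of the two numbers. Compound 2, `CCCCOC(=O)Nc1ccc([Se][Se]c2ccc(NC(=O)OCCCC)cc2)cc1`, gives 7.3% in this assay; this number lies within the scatter of that of compound 1, so the two cannot be ordered. Among the compounds with values here, no step between measured compounds that differ in one place is available.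

Compound 3, `N#C[Se]c1ccc(NC(=O)Oc2ccccc2)cc1`, has not yet been measured. It differs from compound 1 in one place: phenyl in place of butyl on an oxygen next to a carbonyl group. Within the data shown here, with no measured step to lean on, the only guide is that compound 1 and compound 2 give numbers within the scatter of each other. The step of a number 0.6 percentage points lower from compound 1 to compound 3 (within the scatter) is therefore expected to be none beyond the scatter. Compound 3 is estimated to give 12% in this assay, within a range of 2% to 25%.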

Compound 3, a percentage reported as inhibition, at one concentration (the size of the read-out at that concentration, not a potency): > 25%
Compound 3 gave a limit, no number (the forecaster's own chance of this, stated with the estimate: 5%); at least 13 percentage points between middle value and limit.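

In this assay, phenyl in place of butyl on an oxygen next to a carbonyl group gives a number at least 12.4 percentage points higher from compound 1 to compound 3 (beyond the scatter), the only step shown here and one that shows this position can respond to a change of group. Compound 3 gives > 25% in this assay, and this is a limit of the assay, not a number. The full size of the step therefore stays unknown, because the value of compound 3 is a limit: the limit of > 25% in this assay, at which 1 of the 3 values shown sits.

The compounds shown leave open whether a hexyl chain or a cyclohexyl ring on the same oxygen would shift the read-out as phenyl does. They also leave open whether phenyl in place of butyl would do the same on compound 2.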